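This account rests on a few compounds, and the source may have more. Where it says the series, first, only, none or still open, it means among the compounds named here.

Three nucleoside analogues sharing one core have been tested in a functional assay on CCRF-CEM cells (Homo sapiens) for inhibition; a lower number here means a stronger inhibitor, a higher number a weaker inhibitor. Compound 2 `OC[C@H]1OC(n2cnc3c(-c4cc[nH]n4)ncnc32)[C@H](O)[C@@H]1O` gives 750 nM. Compound 3 `OC[C@H]1OC(n2cnc3c(-c4ccc(O)cc4)ncnc32)[C@H](O)[C@@H]1O` gives 1250 nM. Compound 1 `Cc1cc(-c2ncnc3c2ncn3C2O[C@H](CO)[C@@H](O)[C@H]2O)on1` is reported only as "not active" (no number reported), with no number attached. Of the two numbers, that of compound 2 is the lower, yet the step of a 1.7-fold higher number from compound 2 to compound 3 (0.22 log units; within the scatter) lies within the scatter, so compound 2 and compound 3 cannot be told apart on these data.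

Compound 4 `Cn1nccc1-c1ncnc2c1ncn2C1O[C@H](CO)[C@@H](O)[C@H]1O` has not been measured. It differs from compound 2 in a single place: 1-methyl-1H-pyrazol-5-yl in place of 1H-pyrazol-3-yl on an aromatic carbon. Within the data shown here, one measured step touches the same place, the swap from compound 2 to compound 3, which changed nothing beyond the scatter. Compound 1 also carries a different group at that spot and gives no number at all, which shows that this position can matter. The change to compound 4 removes the one hydrogen-bond donor of the leaving group and brings in a group with none, and it adds a methyl. I therefore expect a modest weakening for compound 4, a 2.7-fold higher number from compound 2 to compound 4 (0.43 log units; beyond the scatter), with some chance that no number is reported. Compound 4 is estimated at 2000 nM, within a range from 700 nM to 6000 nM.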

Compound 4, half-maximal inhibitory concentration: "not active" (no number reported)
Compound 4 has no reported number here; no gap can be computed for the estimate.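

In this assay compound 4 gives "not active" (no number reported) and so offers no number to set against compound 2, which means no new step can be read. No further measurement here bears on this result. The compounds shown leave open how much weaker than compound 2 either compound 4 or compound 1 is, if at all.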